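Swapping a nitro for a methyl on a chromone core

The compounds below may be only part of what the source reports. "The series", "measured", "known", "first", "only" and "open" are said of these compounds alone.

Measured compounds:
Compound 1, `O=c1cc(-c2ccccc2)oc2ccc(N3COc4c(cccc4[N+](=O)[O-])C3)cc12`, 61.9%
Compound 2, `O=c1cc(-c2ccccc2)oc2cc(N3COc4c(Cl)cc(Cl)cc4C3)ccc12`, 34.6%
Compound 3, `O=c1cc(-c2ccccc2)oc2cc(N3COc4c(Br)cc(Br)cc4C3)ccc12`, 11.1%

In a functional assay on MCF7 cells (Homo sapiens) for inhibition, read by MTT assay, with a stated time of 48 h, tested at 30 ug/mL (a lower number here means less inhibition of growth, a higher number more inhibition of growth at the concentration tested), compound 1 gives the highest of the three numbers. Its nearest neighbour is compound 2 with 34.6%, a gap beyond the scatter, and the furthest is compound 3 with 11.1%, also beyond the scatter. Compound 4, `Cc1cccc2c1OCN(c1ccc3oc(-c4ccccc4)cc(=O)c3c1)C2`, is not yet measured. It differs from compound 1 in one place: methyl in place of nitro on an aromatic carbon. Among the compounds with values here, no measured pair shows this exact change, so its effect is not known from the numbers here. Compound 4 is expected to give 40%, with a likely range from 20% to 60%. That would mean an expected step of a number 21.9 percentage points lower from compound 1 to compound 4 (beyond the scatter), a drop beyond the scatter, though far from certain.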

Compound 4, percent growth inhibition at one concentration: 72.4%
Compound 4: middle estimate off by 32.4 percentage points, on the low side; the measured number lies above the stated range.
By their numbers in this assay, from the lowest: compound 3; then compound 2; then compound 1; then compound 4.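

In this assay, the nitro is not needed at this position for growth inhibition: methyl in its place gives a number 10.5 percentage points higher from compound 1 to compound 4 (beyond the scatter), a modest step. This position, ortho to a fused ring, therefore accepts a single-carbon group with no hydrogen-bond acceptors, and inhibition does not fall. Nothing measured here says why the step goes this way.

As far as these compounds go, whether an amine, a methoxy group or a longer chain such as ethyl at this position would raise inhibition further remains open. Compounds 2 and 3 differ from compound 1 in more than one place, so they cannot answer this.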